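The compounds below may be only part of what the source reports. "The series", "measured", "known", "first", "only" and "open" are said of these compounds alone.

Measured compounds:
compound 1, `N#CC1=C(N)N(c2ccc(S(N)(=O)=O)cc2)C2=C(C(=O)CCC2)C1c1ccc(O)cc1`, in a functional assay on Ehrlich cells (Mus musculus) for antiproliferative activity, read by trypan blue exclusion, with a stated time of 2 h, tested at 25 ug/mL; a higher number here means a stronger effect of the compound at the concentration tested, a lower number a weaker effect: 95%
compound 2, `N#CC1=C(N)N(c2ccc(S(N)(=O)=O)cc2)C2=C(C(=O)CCC2)C1c1ccc([N+](=O)[O-])cc1`: 80%
compound 3, `N#CC1=C(N)N(c2ccc(S(N)(=O)=O)cc2)C2=C(C(=O)CCC2)C1c1ccc(Cl)cc1Cl`: 50%

Compound 3 stands lowest of the three numbers in this assay. The two steps that lead to it are a number 45 percentage points lower from compound 1 to compound 3 (beyond the scatter) and a number 30 percentage points lower from compound 2 to compound 3 (beyond the scatter); the remaining step among the measured compounds is a number 15 percentage points lower from compound 1 to compound 2 (beyond the scatter).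

Compound 4, `Cc1ccoc1C1C(C#N)=C(N)N(c2ccc(S(N)(=O)=O)cc2)C2=C1C(=O)CCC2`, differs from compound 3 at the saturated ring carbon: 3-methylfuran-2-yl in place of 2,4-dichlorophenyl on a saturated ring carbon. Among the compounds with values here, the steps that bear on this change are the two that also exchange the group on that carbon, a number 45 percentage points lower from compound 1 to compound 3 (beyond the scatter), a large one, and a number 30 percentage points lower from compound 2 to compound 3 (beyond the scatter), a modest one. Both show that an exchange at this position can move the number in this assay well beyond the scatter. Within the data shown here, neither step, however, involves a 3-methylfuran-2-yl group, and no measured pair fixes the direction for it. Among the measured compounds shown here, the only guidance is that compound 3 sits at the bottom of the measured range, so there is more room upward than downward. On this basis the step of a number 10 percentage points higher from compound 3 to compound 4 (within the scatter) is expected to be small, possibly within the scatter, with a lean upward. Compound 4 is therefore estimated at 60% in this assay, with a range from 35% to 85%.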

Compound 4, a percentage reported as activity, at one concentration (the size of the read-out at that concentration, not a potency): 10%
Estimate against measurement, compound 4: 50 percentage points above; the measured number lies below the stated range.
By their numbers in this assay, from the lowest: compound 4; then compound 3; then compound 2; then compound 1.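

In this assay, the exchange at the saturated ring carbon reaches lower than any earlier step, a number 40 percentage points lower from compound 3 to compound 4 (beyond the scatter), so the 2,4-dichlorophenyl group no longer marks the bottom of the series and the 3-methylfuran-2-yl group takes that place. The wider steps, a number 70 percentage points lower from compound 2 to compound 4 (beyond the scatter) and a number 85 percentage points lower from compound 1 to compound 4 (beyond the scatter), show that the group on this one carbon, with the rest of the molecule unchanged, can separate a strong effect from a weak one at the concentration tested, and all three compounds with a substituted phenyl group stand above the one with the five-membered ring. Within the data shown here, nothing available explains why this exchange lowers the number so far.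

The compounds shown leave open whether the low number goes with the furan ring itself or with its methyl group, since neither an unsubstituted furan-2-yl nor a thiophen-2-yl group stands among them. They also leave open how a 4-aminophenyl or 4-methoxyphenyl group on this carbon would compare with the 4-hydroxyphenyl group of compound 1.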